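Removing a thiophen-2-yl group from two cores: cytotoxicity

The source may report more compounds than this note shows. Statements on the series, on what has been measured and on what is new or still open speak of the compounds shown alone.

Three compounds were measured in an ADME assay on MDCK cells (Canis lupus familiaris) for cytotoxicity, read by MTT assay, with a stated time of 2 days; a lower number here means that less compound is tolerated, a higher number that more compound is tolerated:

compound 1, `[N-]=[N+]=NCCCc1ccc(-c2ccc(-c3ccc(-c4cccs4)s3)s2)s1`, gives > 100000 nM, a limit of the assay.
compound 3, `[N-]=[N+]=NCCCc1ccc(-c2ccc(-c3cccs3)s2)s1`, gives > 200000 nM, a limit of the assay.
compound 2, `O=C(NCCCCc1ccc(-c2cccs2)s1)c1cc(F)cc(C(F)(F)F)c1`, gives 27400 nM.

Compound 1 and compound 3 differ by hydrogen in place of thiophen-2-yl on an aromatic carbon, and the step that the two limits leave unreadable from compound 1 to compound 3 cannot be read because both values are limits, as shown by the limit of > 100000 nM in this assay, at which 1 of the 3 values shown sits, and (the limit of > 200000 nM in this assay, at which 1 of the 3 values shown sits). Within the data shown here, compound 2 carries the only number among the three; the difference between its core and the core of compound 1 is not broken down here.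

Compound 4, `O=C(NCCCCc1cccs1)c1cc(F)cc(C(F)(F)F)c1`, has not yet been measured. It differs from compound 2 by hydrogen in place of thiophen-2-yl on an aromatic carbon, the same change as from compound 1 to compound 3, at a place described in identical words. Because the step that the two limits leave unreadable from compound 1 to compound 3 cannot be read, the expectation for compound 4 in this assay rests mainly on the value of compound 2, 27400 nM, and on the small size of the change. The step from compound 2 to compound 4 is expected to be a 1.5-fold higher number from compound 2 to compound 4 (0.16 log units; within the scatter). Compound 4 is estimated at 40000 nM, with a range from 15000 nM to 110000 nM.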

Compound 4, half-maximal cytotoxic concentration: 43500 nM
Beside the measured number, compound 4's estimate is 1.1-fold (0.04 log units) below it; measured number inside the range.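

In this assay, putting hydrogen in place of thiophen-2-yl on the core of compound 2 gives a 1.6-fold higher number from compound 2 to compound 4 (0.20 log units; within the scatter), so in this core the change shows no difference that can be told from the scatter of the assay, though this one pair cannot show how the change behaves in any other core. The same change from compound 1 to compound 3 cannot be read and cannot be set beside this step, because the value of compound 1 is a limit of the assay: the limit of > 100000 nM in this assay, at which 1 of the 4 values shown sits. The value of compound 3 is a limit as well, so the compounds shown do not establish whether the change carries from one core to the other: the limit of > 200000 nM in this assay, at which 1 of the 4 values shown sits.

Open, on these data alone, is how this assay would read with an amine or a carboxylic acid in place of that hydrogen. Among these compounds, also open is whether the result for this change would hold on a longer chain than the one in compound 2 and compound 4.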